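Aryl swap at the shared core: from compound 1 to compound 4

The compounds below may be only part of what the source reports. "The series", "measured", "known", "first", "only" and "open" are said of these compounds alone.

The series keeps one core and varies the aromatic ring attached to it. In a functional assay on SGC-7901 cells (Homo sapiens) for antiproliferative activity, read by MTT assay, with a stated time of 72 h (a lower number here means a stronger inhibitor, a higher number a weaker inhibitor), compound 1 `COc1cc(-n2cnc3ccc(-c4cc(F)ccc4F)cc32)cc(OC)c1OC` gives 6590 nM, the highest number of the three measured compounds, and its steps to both others lie beyond the scatter. Compound 2 `COc1cc(-n2cnc3ccc(-c4cccc([N+](=O)[O-])c4)cc32)cc(OC)c1OC` gives 380 nM in this assay, and compound 3 `COc1cc(-n2cnc3ccc(-c4ccc(Cl)cc4)cc32)cc(OC)c1OC` gives 1270 nM. The step of a 17-fold lower number from compound 1 to compound 2 (1.24 log units; beyond the scatter) is large; the step of a 5.2-fold lower number from compound 1 to compound 3 (0.72 log units; beyond the scatter) is modest; between the two substituted compounds the step of a 3.3-fold higher number from compound 2 to compound 3 (0.52 log units; beyond the scatter) is modest as well.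

Compound 4 `COc1cccc(-c2ccc3ncn(-c4cc(OC)c(OC)c(OC)c4)c3c2)c1` is not yet measured in this assay. It differs from compound 1 as follows: 3-methoxyphenyl in place of 2,5-difluorophenyl on an aromatic carbon. The two measured steps that start from compound 1 bear on this change directly, since each replaces the same 2,5-difluorophenyl with another singly substituted phenyl, and both lowered the number beyond the scatter, by a 17-fold lower number from compound 1 to compound 2 (1.24 log units; beyond the scatter) and by a 5.2-fold lower number from compound 1 to compound 3 (0.72 log units; beyond the scatter). A lower number is therefore expected for compound 4, most likely of modest size. The expected step is a 4.4-fold lower number from compound 1 to compound 4 (0.64 log units; beyond the scatter). In this assay compound 4 is estimated at 1500 nM, with a range from 500 nM to 4500 nM.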

Compound 4, half-maximal inhibitory concentration: 3310 nM
Estimate against measurement, compound 4: 2.2-fold (0.34 log units) below, within the range that was stated.
By their numbers in this assay, from the lowest: compound 2; then compound 3; then compounds 4 and 1 (each within the scatter of the next).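

In this assay the 3-methoxyphenyl group does not separate from 2,5-difluorophenyl, with a 2.0-fold lower number from compound 1 to compound 4 (0.30 log units; within the scatter) as the whole step, so replacing 2,5-difluorophenyl with a singly substituted phenyl does not by itself bring a lower number; compound 4 goes against the trend that compound 2 and compound 3 suggested. The group carried on that phenyl therefore counts at this position: the one-place change of methoxy in place of nitro gives an 8.7-fold higher number from compound 2 to compound 4 (0.94 log units; beyond the scatter) and is the clearest reading of the group alone. The comparison with the chloro compound points the same way, with a 2.6-fold higher number from compound 3 to compound 4 (0.42 log units; beyond the scatter) as a modest step, although that pair changes both the group and where it sits on the phenyl.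

As far as these compounds go, whether the low number of compound 2 belongs to the nitro group alone stays open: an amine, a nitrile or a carboxylic acid in place of the nitro would test that, and a 4-methoxyphenyl set against the 3-methoxyphenyl would separate the group from its place on the ring. Nothing available gives a reason for these differences.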